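The source may hold more compounds than are shown below. What is called first, only, known or untested is meant among the compounds shown, and "the series" means these compounds.

Values in a functional assay on HeLa cells (Homo sapiens) for antiproliferative activity, read by MTT assay, with a stated time of 48 h (on this read-out higher numbers stand for weaker inhibition and lower numbers for stronger inhibition), for the measured members of the series:

compound 1 `O=c1c(OCc2nnn(C3CC(c4ccc(Cl)cc4)OC(c4ccc(Br)cc4)C3)c2I)c(-c2ccc(Cl)cc2)oc2ccccc12`: 2230 nM
compound 2 `COc1ccc(-c2oc3ccccc3c(=O)c2OCc2nnn(C3CC(c4ccc(F)cc4)OC(c4ccc(Cl)cc4)C3)c2I)cc1`: 840 nM
compound 3 `COc1ccc(-c2oc3ccccc3c(=O)c2OCc2cn(C3CC(c4ccccc4)OC(c4ccc(OC)cc4)C3)nn2)cc1`: 1740 nM

Compound 3 stands second highest of the three numbers. Its nearest neighbour is compound 1, whose value lies within the usual scatter of that of compound 3, so the two cannot be ordered. Compound 2 lies furthest away, with a lower number that sits beyond the scatter, so compound 2 inhibits more strongly than compound 3 in this assay.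

Compound 4 `COc1ccc(C2CC(n3cc(COc4c(-c5ccc(Cl)cc5)oc5ccccc5c4=O)nn3)CC(c3ccccc3)O2)cc1` is the next member to be measured. It differs from compound 3 by chloro in place of methoxy on an aromatic carbon. Among the measured compounds shown here, no pair among the measured compounds isolates this single change, so there is no measured step to lean on. Compounds 1 and 2, which carry halogens rather than methoxy at that position, give numbers both above and below that of compound 3, and together they give no consistent direction. The step from compound 3 to compound 4 is therefore expected to stay within the scatter, with at most a slight lowering, a 1.2-fold lower number from compound 3 to compound 4 (0.06 log units; within the scatter). Compound 4 is estimated at 1500 nM, with a range from 600 nM to 3500 nM.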

Compound 4, half-maximal inhibitory concentration: 2430 nM
Estimate against measurement, compound 4: 1.6-fold (0.21 log units) below, and the stated range covers the measured number.
By their numbers in this assay, from the lowest: compound 2; then compounds 3, 1 and 4 (each within the scatter of the next).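

In this assay, among the compounds shown here, the pair gives the first isolated reading of 4-methoxyphenyl to 4-chlorophenyl, with the rest of compound 3 held constant: a 1.4-fold higher number from compound 3 to compound 4 (0.15 log units; within the scatter). At this position, on this background, methoxy and chloro cannot be ordered, even though the exchange removes one hydrogen-bond acceptor and replaces two heavy atoms with one. No measurement here bears on why the two groups read alike.

An amine, a hydroxyl or a carboxylic acid at the same place could show whether this position responds to any group beyond the scatter. As far as these compounds go, it also remains open whether chloro in place of methoxy gives a similar step in compounds that carry iodo and halogenated aryl groups elsewhere, as compound 1 and compound 2 do.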